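A few compounds are considered here, and "the series" means these few. Any claim that something is new, unique, unknown or untested is made for them only; others in the source may bear on it.

In a functional assay on KB cells (Homo sapiens) for antiproliferative activity, read by sulforhodamine B assay, with a stated time of 3 days (a higher number here means that more compound is needed for the effect, a lower number that less compound is needed), compound 1 `CCC1=C(O)c2c(oc(-c3ccc(F)cc3)cc2=O)C(CC)(CC)C1=O` gives 33 uM and compound 3 `CCC1=C(O)c2c(oc(-c3cc(C)c(C)cc3C)cc2=O)C(CC)(CC)C1=O` gives 8.2 uM, the lower of these two numbers. For compound 2 `CCC1=C(O)c2c(oc(-c3ccccc3F)cc2=O)C(CC)(CC)C1=O` the assay reports only a limit, > 56.2 uM. Compound 4 `CCC1=C(O)c2c(oc(-c3ccc(O)c(O)c3)cc2=O)C(CC)(CC)C1=O` carries 3,4-dihydroxyphenyl in place of 2,4,5-trimethylphenyl on the shared core: 3,4-dihydroxyphenyl in place of 2,4,5-trimethylphenyl on an aromatic carbon. The measured steps bearing on this change swap the same group: a 4.0-fold lower number from compound 1 to compound 3 (0.60 log units; beyond the scatter) and an at least 6.8-fold lower number from compound 2 to compound 3 (0.83 log units; beyond the scatter), both beyond the scatter. Both fluorophenyl compounds sit on the higher side of compound 3 at 8.2 uM, so losing the trimethylphenyl group is expected to raise the number modestly in this assay. The expected change is a 2.9-fold higher number from compound 3 to compound 4 (0.47 log units; beyond the scatter). For compound 4 the estimated value is 24 uM, with an expected range of 7 uM to 56 uM.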

Compound 4, concentration for half-maximal effect: 10 uM
For compound 4 the middle estimate is 2.4-fold (0.38 log units) above the measured one; measured number inside the range.
By their numbers in this assay, from the lowest: compounds 3 and 4 (each within the scatter of the next); then compound 1. At a limit, above all of these: compound 2.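

Swapping 2,4,5-trimethylphenyl for 3,4-dihydroxyphenyl changes little in this assay (a 1.2-fold higher number from compound 3 to compound 4 (0.09 log units; within the scatter)), even though the two groups differ in hydrogen-bond donors. Compound 4 also stands apart from both fluorophenyl compounds (a 3.3-fold lower number from compound 1 to compound 4 (0.52 log units; beyond the scatter); an at least 5.6-fold lower number from compound 2 to compound 4 (0.74 log units; beyond the scatter)), so a low number at this position does not depend on the methyl groups. The second of those steps is only a floor, set by compound 2: the limit of > 56.2 uM in this assay, at which 1 of the 4 values shown sits.

As far as these compounds go, whether both hydroxyl groups are needed stays open, as does whether a methoxy group, an amine or a carboxylic acid would keep the number this low.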